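The source may report more compounds than this note shows. Statements on the series, on what has been measured and on what is new or still open speak of the compounds shown alone.

Measured compounds:
Compound 1, `CCCNc1cc(-c2ccccc2)nc2cc(OC)cc(OC)c12`, in a functional assay on DU-145 cells (Homo sapiens) for inhibition, read by MTT assay, with a stated time of 72 h (a lower number here means a stronger inhibitor, a higher number a weaker inhibitor), gives 9770 nM.
Compound 2, `COc1cc(OC)c2c(-n3ccnc3)cc(-c3ccccc3)nc2c1`, in this assay gives only a limit, > 100000 nM.
Compound 3, `COc1cc(OC)c2c(N3CCCCC3)cc(-c3ccccc3)nc2c1`, in this assay gives only a limit, > 100000 nM.

Compound 3 therefore stands at the limit of the assay, not at a number, and it shares that limit with compound 2 (the limit of > 100000 nM in this assay, at which 2 of the 3 values shown sit). Compound 4, `COc1cc(OC)c2c(NCc3ccccc3)cc(-c3ccccc3)nc2c1`, is not yet measured. It differs from compound 3 in one place: benzylamino in place of piperidin-1-yl on an aromatic carbon.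

Among the compounds with values here, two measured steps bear on this. Replacing the propylamino of compound 1 by an imidazolyl gave an at least 10-fold higher number from compound 1 to compound 2 (1.01 log units; beyond the scatter), and replacing it by a piperidinyl gave an at least 10-fold higher number from compound 1 to compound 3 (1.01 log units; beyond the scatter). The step that the two limits leave unreadable from compound 2 to compound 3 tells nothing, as both ends are limits. Both groups that weakened the inhibitor lack a hydrogen-bond donor, while compound 1 and compound 4 each carry one. Going back from compound 3 to a group with a donor is thus expected to lower the number, although its size is not readable from a limit.

Compound 4 is expected to give 12000 nM, with a range from 3000 nM to 60000 nM. The expected step is an at least 8.3-fold lower number from compound 3 to compound 4 (0.92 log units; beyond the scatter).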

Compound 4, half-maximal inhibitory concentration: 10100 nM
The estimate for compound 4 lay 1.2-fold (0.07 log units) above the measured number; measured number inside the range.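

At this position, opposite the ring nitrogen, a second group with a hydrogen-bond donor gives a readable number in this assay: benzylamino in place of piperidin-1-yl gives an at least 9.9-fold lower number from compound 3 to compound 4 (0.99 log units; beyond the scatter), and in place of 1H-imidazol-1-yl it gives an at least 9.9-fold lower number from compound 2 to compound 4 (0.99 log units; beyond the scatter). Both steps start from limits of the assay, not from numbers: the limit of > 100000 nM in this assay, at which 2 of the 4 values shown sit. The end of the chain makes no readable difference here, as phenyl in place of ethyl gives a 1.0-fold higher number from compound 1 to compound 4 (0.01 log units; within the scatter).

No pair shown differs only in the hydrogen-bond donor, so whether the donor itself is what counts stays open. Also open, going by these compounds, is how a plain amino group or a longer chain such as 3-phenylpropylamino would read at this position.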